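A few compounds are considered here, and "the series" means these few. Any claim that something is new, unique, unknown or untested is made for them only; others in the source may bear on it.

Measured so far:
compound 1 `Cc1cc(-c2cnc(NCc3c(F)ccc4c3CCO4)c3cn[nH]c(=O)c23)n(C)n1` — 3
compound 2 `Fc1ccc2c(c1CNc1ncc(Oc3ccccc3)c3nncn13)CCO2` — 3.5

In a physicochemical assay for lipophilicity, using the shake flask method, in phosphate buffer, measured as octanol-water partition, with a stated time of 30 min, at pH 7.4 (on this read-out lower numbers stand for lower lipophilicity and higher numbers for higher lipophilicity), compound 1 gives 3 and compound 2 gives 3.5. Compound 2 therefore stands highest of the two; compound 1, its nearest neighbour, lies a gap below it that is beyond the usual scatter. Compound 3 `C[C@H]1CC(=O)N(c2cnc(NCc3c(F)ccc4c3CCO4)n3cnnc23)C1` has not yet been measured. It differs from compound 2 in one place: 4-methyl-2-oxopyrrolidin-1-yl in place of phenoxy on an aromatic carbon. Going by the values given here, no measured pair shows this change, so its effect can only be expected: a downward step, a number 1.20 log units lower from compound 2 to compound 3 (beyond the scatter), beyond the scatter, is expected. Compound 3 is estimated at 2.3, between 1.7 and 2.9.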

Compound 3, distribution coefficient: 1.8
For compound 3 the middle estimate is 0.50 log units above the measured one; low and high end bracket the measured number.
By their numbers in this assay, from the lowest: compound 3; then compound 1; then compound 2.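

In this assay, going by these compounds alone, this is the first one-place change that can be read, and replacing phenoxy with 4-methyl-2-oxopyrrolidin-1-yl on this aromatic carbon gives a large step: a number 1.70 log units lower from compound 2 to compound 3 (beyond the scatter). The read-out at this position therefore responds strongly to the group placed there, even though both groups have the same heavy-atom count and the same hydrogen-bond donor and acceptor counts. No measurement shown here explains the drop. Going by these compounds, whether an amine, a carboxylic acid or a longer chain at this position would give a similar number remains open. A single pair also cannot show whether the same change would give a similar step on another core.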